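The source may hold more compounds than are shown below. What is called first, only, known or untested is meant among the compounds shown, and "the series" means these compounds.

Three measured compounds share one core and differ only in the aryl group on a double-bonded chain carbon. In a functional assay on K562 cells (Homo sapiens) for antiproliferative activity, read by MTT assay, with a stated time of 24 h (on this read-out higher numbers stand for weaker inhibition and lower numbers for stronger inhibition), compound 1 `COc1ccc(C(=O)/C=C/c2ccc(Br)cc2)c2c1C=CC(C)(C)O2` gives no number but a limit, > 10000 nM, which is the limit of > 10000 nM in this assay, at which 1 of the 3 values shown sits. Compound 2 `COc1ccc(C(=O)/C=C/c2ccc([N+](=O)[O-])cc2)c2c1C=CC(C)(C)O2` gives 7770 nM in this assay. Compound 3 `COc1ccc(C(=O)/C=C/c2ccc(Cl)c(Cl)c2)c2c1C=CC(C)(C)O2` gives 9030 nM in this assay, the highest of the two numbers shown; its nearest neighbour is compound 2, and the step of a 1.2-fold higher number from compound 2 to compound 3 (0.07 log units; within the scatter). The step of an at least 1.1-fold lower number from compound 1 to compound 3 (0.04 log units; that floor lies within the scatter) is likewise small.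

Compound 4 `COc1ccccc1/C=C/C(=O)c1ccc(OC)c2c1OC(C)(C)C=C2` carries the change (2-methoxyphenyl in place of 3,4-dichlorophenyl on a double-bonded chain carbon bound to a double-bonded chain carbon). Among the measured compounds shown here, the steps that bear on it are the two exchanges of the aryl group at the same place, from compound 1 and from compound 2 to compound 3, and neither of them moved the number beyond the scatter. The step of a 1.2-fold lower number from compound 3 to compound 4 (0.08 log units; within the scatter) is therefore expected to be small as well, with no clear direction. Compound 4 is estimated to give about 7500 nM in this assay, in a range from 2500 nM to 25000 nM.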

Compound 4, half-maximal inhibitory concentration: > 10000 nM
Compound 4: no number, only a limit; the forecaster's own chance of this, stated with the estimate: 30%; middle value at least 1.3-fold (0.12 log units) from the limit.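

With 2-methoxyphenyl at this place, compound 4 also gives only a limit in this assay, which adds a second aryl group to those that reach it: the limit of > 10000 nM in this assay, at which 2 of the 4 values shown sit. The exchange gives an at least 1.1-fold higher number from compound 3 to compound 4 (0.04 log units; that floor lies within the scatter) and an at least 1.2-fold higher number from compound 2 to compound 4 (0.10 log units; that floor lies within the scatter), so a methoxy-bearing ring, like the bromo, nitro and dichloro rings before it, gives no step beyond the scatter, and the true size of both steps stays hidden behind the limit. The step between compound 1 and compound 4 cannot be read.

As far as these compounds go, whether a phenyl ring bearing an amine or a hydroxyl group at this place would bring the number down remains open. So does the question of whether a pyridine ring in place of the phenyl ring, or a change elsewhere on the shared core, would do so.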